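Replacing the Amide Side Chain of Compound 1

This account rests on a few compounds, and the source may have more. Where it says the series, first, only, none or still open, it means among the compounds named here.

In a functional assay on MCF7 cells (Homo sapiens), read by MTT assay, with a stated time of 48 h (on this read-out higher numbers stand for weaker inhibition and lower numbers for stronger inhibition), compound 1 `CCN(CC)CCNC(=O)c1ccc(C(CC)(CC)c2ccc(OCC(=O)C(C)(C)C)c(C)c2)n1CC` gives 690 nM, level with compound 2 `CCN(CC)CCNC(=O)c1ccc(C(CC)(CC)c2ccc(OCC(O)C(C)(C)C)c(C)c2)n1CC` at 690 nM. Together they hold the highest number of the series, while compound 3 `CCN(CC)CCCNC(=O)c1ccc(C(CC)(CC)c2ccc(OCC(O)C(C)(C)C)c(C)c2)n1CC` gives 190 nM. Compound 4 `CCn1c(C(=O)N(C)CC(=O)O)ccc1C(CC)(CC)c1ccc(OCC(=O)C(C)(C)C)c(C)c1` has not yet been measured. It differs from compound 1 on a carbonyl carbon, with (carboxymethyl)(methyl)amino in place of (2-(diethylamino)ethyl)amino on a carbonyl carbon.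

Two measured steps offer limited guidance. The first, no change at the digits printed from compound 1 to compound 2 (within the scatter), lies elsewhere in the molecule and says little about this change. The second, a 3.6-fold lower number from compound 2 to compound 3 (0.56 log units; beyond the scatter), shows that this assay responds to the amide side chain, but it only extends that chain. From the compounds shown here alone, all three measured compounds retain the diethylamino group, so its removal is untested. A larger step than the second is therefore expected, towards a higher number, though with considerable uncertainty. The expected change is a 4.3-fold higher number from compound 1 to compound 4 (0.64 log units; beyond the scatter). The estimated value for compound 4 is 3000 nM, within an expected range of 500 nM to 20000 nM.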

Compound 4, half-maximal inhibitory concentration: 28600 nM
Compound 4: the middle estimate sits 9.5-fold (0.98 log units) below what was measured; measured number outside the range, above it.
By their numbers in this assay, from the lowest: compound 3; then compounds 1 and 2 (each within the scatter of the next); then compound 4.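

In this assay, within the data shown here, the amide side chain proves to matter far more than the earlier compounds showed, with a 41-fold higher number from compound 1 to compound 4 (1.62 log units; beyond the scatter). Among these compounds, this step is the first to remove the diethylamino group, and it is larger than the one seen on extending the chain, a 3.6-fold lower number from compound 2 to compound 3 (0.56 log units; beyond the scatter). No supporting evidence is available to explain the rise.

The single swap on the carbonyl carbon removes the diethylamino group, brings in a carboxylic acid and adds a methyl group on the amide nitrogen, so the compounds shown cannot separate the contribution of each. From the compounds shown here alone, it remains open whether a methyl ester in place of the carboxylic acid, or a (2-(diethylamino)ethyl)(methyl)amino group in place of the original side chain, would keep the number close to that of compound 1.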